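The compounds below may be only part of what the source reports. "The series", "measured", "known", "first", "only" and "open" are said of these compounds alone.

Measured so far:
compound 1, `CCc1nc(SC)c2n1CCN([C@@H](C(=O)NC)c1ccccc1)[C@H]2CCc1ccc(C(F)(F)F)cc1`, 85 nM
compound 2, `CCc1nc(C)c2n1CCN([C@@H](C(=O)NC)c1ccccc1)C2CCc1ccc(C(F)(F)F)cc1`, 10000 nM

Among the compounds with values here, in a functional assay on CHO cells for antagonist activity at Orexin/Hypocretin receptor type 1 (Homo sapiens), read by FLIPR and calcium flux (a lower number here means a stronger inhibitor, a higher number a weaker inhibitor), compound 1 gives the lowest of the two numbers; compound 2 gives a higher number, beyond the scatter, and no single-change step between the two has been worked out. Compound 3, `CCc1nc(C2CC2)c2n1CCN([C@@H](C(=O)NC)c1ccccc1)[C@H]2CCc1ccc(C(F)(F)F)cc1`, is not yet measured. It differs from compound 1 in one place: cyclopropyl in place of methylsulfanyl on an aromatic carbon. With only compound 1 as a direct reference, a modest step from compound 1 toward a higher number is expected, a 1.8-fold higher number from compound 1 to compound 3 (0.25 log units; within the scatter), though it may fall within the scatter. Compound 3 is estimated at 150 nM, in the range 40 nM to 800 nM.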

Compound 3, half-maximal inhibitory concentration: 4170 nM
Compound 3: the middle estimate sits 28-fold (1.44 log units) below what was measured; the measured number lies above the stated range.
By their numbers in this assay, from the lowest: compound 1; then compound 3; then compound 2.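

In this assay, the aromatic carbon next to the ring nitrogen proves far from indifferent to its substituent: cyclopropyl in place of methylsulfanyl brings a 49-fold higher number from compound 1 to compound 3 (1.69 log units; beyond the scatter). On the core of compound 1, then, exchanging this one group is enough to weaken the inhibitor markedly. Nothing available explains why the step is so large. The compounds shown leave open whether a methoxy group, an ethylsulfanyl chain or an amine on this carbon would stay close to compound 1 or fall toward compound 3.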